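Urea aryl swap on the shared core: expecting compound 4

The source may report more compounds than this note shows. Statements on the series, on what has been measured and on what is new or still open speak of the compounds shown alone.

Measured compounds:
compound 1, `Nc1n[nH]c2cccc(-c3cccc(NC(=O)Nc4ccc(Cl)cc4Cl)c3)c12`: 1900 nM
compound 2, `Nc1n[nH]c2cccc(-c3cccc(NC(=O)Nc4ccc(F)c(F)c4)c3)c12`: 5880 nM
compound 3, `Nc1n[nH]c2cccc(-c3cccc(NC(=O)Nc4cc(C(F)(F)F)cc(C(F)(F)F)c4)c3)c12`: 3540 nM

In a functional assay on SMMC-7721 cells (Homo sapiens) for inhibition, read by MTT assay, with a stated time of 48 h (on this read-out higher numbers stand for weaker inhibition and lower numbers for stronger inhibition), compound 1 gives the lowest of the three numbers. Compound 3 sits nearest to it, and that gap is within the scatter, so no order between compound 1 and compound 3 can be claimed. Compound 2 lies furthest away, and the step of a 3.1-fold higher number from compound 1 to compound 2 (0.49 log units; beyond the scatter) is beyond the scatter.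

The unmeasured compound 4, `CC(C)c1cccc(NC(=O)Nc2cccc(-c3cccc4[nH]nc(N)c34)c2)c1`, shares the core of compound 1 and differs from it only at the urea end: 3-isopropylphenyl in place of 2,4-dichlorophenyl on an amide-type nitrogen. Going by the values given here, only one measured step touches this part of the molecule, a 3.1-fold higher number from compound 1 to compound 2 (0.49 log units; beyond the scatter), and it moved to a weaker number when the aryl on the amide-type nitrogen was changed. Compound 3 carries yet another aryl there and also gives a higher number than compound 1, though that gap is within the scatter. Among the compounds with values here, both measured variations of this aryl thus gave higher numbers than compound 1, and none gave a lower one, so a modest rise is expected for compound 4 as well, with wide uncertainty because the 3-isopropylphenyl group has no close precedent among the measured compounds.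

The expected step is a 2.1-fold higher number from compound 1 to compound 4 (0.32 log units; beyond the scatter). Compound 4 is therefore estimated at 4000 nM, between 1500 nM and 12000 nM.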

Compound 4, half-maximal inhibitory concentration: 280 nM
The estimate for compound 4 lay 14-fold (1.15 log units) above the measured number, outside the stated range (below it).
By their numbers in this assay, from the lowest: compound 4; then compounds 1, 3 and 2 (each within the scatter of the next, the first and the last beyond it).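

In this assay, the aryl on the amide-type nitrogen proves able to push the number down as well as up: 3-isopropylphenyl in place of 2,4-dichlorophenyl gives a 6.8-fold lower number from compound 1 to compound 4 (0.83 log units; beyond the scatter), whereas no earlier aryl at this place had gone below compound 1 by more than the scatter. Going by these compounds alone, the same position also spans a wider range than the earlier compounds revealed, with the shared core unchanged throughout, as 3-isopropylphenyl in place of 3,4-difluorophenyl gives a 21-fold lower number from compound 2 to compound 4 (1.32 log units; beyond the scatter), a large step from a single change. All the earlier aryl groups carry chlorine or fluorine, while 3-isopropylphenyl is made of carbon only, so a halogen on this aryl is not required for a number in the range of compound 4, which gives 280 nM.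

Within the data shown here, nothing given here accounts for why this change moves the number so far. Going by these compounds, it remains open whether the isopropyl group itself carries the step, and how a smaller ethyl group, a larger tert-butyl group or a methoxy group would read at this place in this assay.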